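One fluoro added to a weakly cytotoxic compound

The compounds below may be only part of what the source reports. "The series", "measured", "known", "first", "only" and "open" are said of these compounds alone.

For the measured compounds named here, in a functional assay on PC-3 cells (Homo sapiens) for cytotoxicity, read by WST assay, with a stated time of 24 h (a lower number here means a stronger inhibitor, a higher number a weaker inhibitor), compound 1 (`COc1ccc2[nH]cc(/C=C(\C#N)C(=O)c3c[nH]c4ccccc34)c2c1`) holds the only actual number so far (33200 nM). Compound 2 (`N#C/C(=C\c1c[nH]c2ccc(Br)cc12)C(=O)c1c[nH]c2ccc(Br)cc12`) gives only a limit, not a number (> 50000 nM). Compound 3 (`COc1ccc2[nH]cc(/C=C(\C#N)C(=O)c3c[nH]c4ccc(OC)cc34)c2c1`) likewise gives only a limit (> 50000 nM). The picture is therefore dominated by the limit of > 50000 nM in this assay, at which 2 of the 3 values shown sit, and compound 1 lies close to that limit.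

The next compound, compound 4 (`COc1ccc2[nH]cc(/C=C(\C#N)C(=O)c3c[nH]c4cc(F)ccc34)c2c1`), differs from compound 1 in one place (fluoro in place of hydrogen on an aromatic carbon): fluoro in place of hydrogen on an aromatic carbon. No fluoro replacement has been measured yet. The nearest guide is another single replacement on an aromatic carbon, methoxy in place of hydrogen, which gave an at least 1.5-fold higher number from compound 1 to compound 3 (0.17 log units; that floor lies within the scatter) and so shows no change beyond the scatter. That step has a different group and only a floor for its size, so it is weak evidence. Going by the values given here, with compound 3 as the only guide (an at least 1.5-fold higher number from compound 1 to compound 3 (0.17 log units; that floor lies within the scatter)), no step beyond the scatter is expected, and the estimate is a 1.1-fold higher number from compound 1 to compound 4 (0.02 log units; within the scatter) as the expected move. Compound 4 is estimated at 35000 nM with an expected range from 16000 nM to 55000 nM around that middle, and it may also turn out to give only a limit.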

Compound 4, half-maximal inhibitory concentration: > 50000 nM
Compound 4 ended at the assay's limit; the forecaster's own chance of this, stated with the estimate: 30%; at least 1.4-fold (0.15 log units) between middle value and limit.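

For the compounds shown here, on an aromatic carbon meta to a fused ring and para to a fused ring, fluoro in place of hydrogen gives, in this assay, an at least 1.5-fold higher number from compound 1 to compound 4 (0.17 log units; that floor lies within the scatter), and this is the first look at a replacement at this position. The one added fluorine atom brings no gain in strength here, and the core of compound 1 now has two single replacements, this fluoro and the earlier methoxy, that both end without a measurable number. How large the true step is cannot be read, and it may be no real change at all, because the floor of the step is set by the assay's ceiling rather than by a measured value for compound 4, a ceiling that now holds most of the series: the limit of > 50000 nM in this assay, at which 3 of the 4 values shown sit.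

What the compounds shown leave open is whether any group on this carbon can bring the number down from the level of compound 1. An amine or a carboxylic acid in place of the fluoro would test this, and a real number below the limit would be needed before this position could be ranked at all.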